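This account rests on a few compounds, and the source may have more. Where it says the series, first, only, none or still open, it means among the compounds named here.

In an ADME assay on Vero cells (Chlorocebus sabaeus) for cytotoxicity, read by reporter gene assay, with a stated time of 4 days (a higher number here means a weaker inhibitor, a lower number a stronger inhibitor), compound 2 `CCCCCCC(=O)NCC(C)(C)CC1=C(O)C(=O)c2ccccc2C1=O` gives 24800 nM, and compound 1 `CCCC(C)C(=O)NCC(C)(C)CC1=C(O)C(=O)c2ccccc2C1=O` gives 48100 nM, so the two stand level within the scatter. Compound 3 `CCCC(C)C(=O)OCC(C)(C)CC1=C(O)C(=O)c2ccccc2C1=O` has ((1-methylbutyl)carbonyl)oxy in place of (hexylcarbonyl)amino (((1-methylbutyl)carbonyl)oxy in place of (hexylcarbonyl)amino on a saturated chain carbon, three bonds along the chain from a double-bonded ring carbon). Within the data shown here, only one measured step bears on this change: a 1.9-fold lower number from compound 1 to compound 2 (0.29 log units; within the scatter). Among the measured compounds shown here, that step concerns the chain alone, and no measured pair shows what swapping the amino link for the oxy link does. No shift beyond the scatter is therefore expected in this assay, though the uncertainty is wide. The estimated change is a 1.2-fold higher number from compound 2 to compound 3 (0.08 log units; within the scatter). The expected value for compound 3 is 30000 nM, with an estimated range of 10000 nM to 85000 nM.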

Compound 3, half-maximal inhibitory concentration: 120 nM
Beside the measured number, compound 3's estimate is 250-fold (2.40 log units) above it, outside the stated range (below it).
By their numbers in this assay, from the lowest: compound 3; then compounds 2 and 1 (each within the scatter of the next).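

In this assay, the link on this saturated chain carbon counts for far more than the chain attached to it. With the 1-methylbutyl group kept, ((1-methylbutyl)carbonyl)oxy in place of ((1-methylbutyl)carbonyl)amino gives a 400-fold lower number from compound 1 to compound 3 (2.60 log units; beyond the scatter), and the step from the hexyl amide gives a 210-fold lower number from compound 2 to compound 3 (2.32 log units; beyond the scatter), whereas the chain change alone stayed within the scatter. Nothing available here accounts for this large difference. Still open, as far as these compounds go, is whether a hexyl chain on the oxy link would behave the same way, and whether a thioester or a simple ether link would do so too.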